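The source may hold more compounds than are shown below. What is called first, only, known or untested is meant among the compounds shown, and "the series" means these compounds.

Compounds measured in a functional assay on CHO cells for agonist activity at Free fatty acid receptor 1 (Homo sapiens), read by FLIPR and calcium flux; on this read-out lower numbers stand for an effect already at smaller amounts and higher numbers for an effect only at larger amounts of compound:
compound 1 `COc1cc(C)c(-c2cccc(COc3ccc(S(=O)(=O)CC(=O)O)cc3)c2)c(C)c1`, 57.5 nM
compound 2 `Cc1ccccc1-c1cccc(COc2ccc(S(=O)(=O)CC(=O)O)cc2)c1`, 46.8 nM
compound 3 `CC(C)c1ccccc1-c1cccc(COc2ccc(S(=O)(=O)CC(=O)O)cc2)c1`, 74.1 nM

In this assay the steps of a 1.3-fold higher number from compound 1 to compound 3 (0.11 log units; within the scatter) and a 1.6-fold higher number from compound 2 to compound 3 (0.20 log units; within the scatter) both lie within the scatter, so compound 3 cannot be set apart from compound 1 or compound 2. Compound 4 `O=C(O)CS(=O)(=O)c1ccc(OCc2cccc(Oc3ccccc3)c2)cc1` differs from compound 3 by phenoxy in place of 2-isopropylphenyl on an aromatic carbon. The measured steps of a 1.2-fold lower number from compound 1 to compound 2 (0.09 log units; within the scatter), a 1.3-fold higher number from compound 1 to compound 3 (0.11 log units; within the scatter) and a 1.6-fold higher number from compound 2 to compound 3 (0.20 log units; within the scatter) only exchange substituents on the pendant ring and all stay within the scatter; none exchanges the directly attached ring for a phenoxy group, so they bear on the new change only loosely. Compound 4 is therefore expected to give a number near those of compound 3, with a wide range: 150 nM (40 nM to 600 nM), meaning an expected step of a 2.0-fold higher number from compound 3 to compound 4 (0.31 log units; beyond the scatter).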

Compound 4, half-maximal effective concentration: 97.7 nM
Compound 4: middle estimate off by 1.5-fold (0.19 log units), on the high side; the range from low to high includes it.
By their numbers in this assay, from the lowest: compounds 2, 1, 3 and 4 (each within the scatter of the next, the first and the last beyond it).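

In this assay the directly attached ring on this aromatic carbon can give way to phenoxy, with its oxygen link, while agonist activity remains in a similar range. Against two of the earlier compounds the change stays small, with a 1.3-fold higher number from compound 3 to compound 4 (0.12 log units; within the scatter) and a 1.7-fold higher number from compound 1 to compound 4 (0.23 log units; within the scatter) and only a 2.1-fold higher number from compound 2 to compound 4 (0.32 log units; beyond the scatter) clears the scatter, so the loss is modest and shows only against the 2-methylphenyl group.

As far as these compounds go, it remains open whether an amine in place of the linking oxygen would behave alike, and whether methoxy or methyl on the phenoxy ring would shift the number. No measurement at hand accounts for these steps.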